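Halogen exchange on the hydrazone aryl ring

The source may report more compounds than this note shows. Statements on the series, on what has been measured and on what is new or still open speak of the compounds shown alone.

Measured compounds:
compound 1 `COc1cc2c(Oc3ccc(NC(=O)N/N=C/c4ccc(C(F)(F)F)cc4)cc3F)ccnc2cc1OCCCN1CCC(C)CC1` — 740 nM
compound 2 `COc1cc2c(Oc3ccc(NC(=O)N/N=C/c4ccc(Cl)cc4Cl)cc3F)ccnc2cc1OCCCN1CCC(C)CC1` — 470 nM

In a functional assay on HT-29 cells (Homo sapiens) for cytotoxicity, read by MTT assay, with a stated time of 72 h (on this read-out lower numbers stand for stronger inhibition and higher numbers for weaker inhibition), compound 2 gives 470 nM, and compound 1 gives 740 nM; the step of a 1.6-fold lower number from compound 1 to compound 2 (0.20 log units; within the scatter) places the two within the scatter of one another, so compound 2 cannot be set apart from compound 1 on these numbers. Compound 3 `COc1cc2c(Oc3ccc(NC(=O)N/N=C/c4ccc(F)cc4Cl)cc3F)ccnc2cc1OCCCN1CCC(C)CC1` differs from compound 2 in one place: fluoro in place of chloro on an aromatic carbon. Among the compounds with values here, the only measured step that bears on this ring is the one from compound 1 to compound 2, where a change of the whole substitution pattern of that ring moved the number within the scatter. A single halogen exchange on the same ring is therefore expected to move the number little, a 1.3-fold higher number from compound 2 to compound 3 (0.11 log units; within the scatter), with no direction claimed beyond the scatter. Compound 3 is estimated at 600 nM, with a range from 250 nM to 1400 nM.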

Compound 3, half-maximal inhibitory concentration: 440 nM
Compound 3: the middle estimate sits 1.4-fold (0.13 log units) above what was measured; measured number inside the range.
By their numbers in this assay, from the lowest: compounds 3, 2 and 1 (each within the scatter of the next).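

In this assay the exchange of chloro for fluoro, on the aromatic carbon para to a large group and meta to a chloro group, gives a 1.1-fold lower number from compound 2 to compound 3 (0.03 log units; within the scatter) and so isolates a single atom at this place, which the earlier step across the whole substitution pattern could not do. These numbers do not separate the two halogens here, and the 2-chloro-4-fluorophenyl ring also remains within the scatter of 4-(trifluoromethyl)phenyl (a 1.7-fold lower number from compound 1 to compound 3 (0.23 log units; within the scatter)). No measurement is available that would account for this result.

The compounds shown leave open whether a group of another kind at this carbon, such as an amine or a carboxylic acid, would give a number beyond the scatter. They also leave open what the chloro group shared by compound 2 and compound 3 contributes.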